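A few compounds are considered here, and "the series" means these few. Any claim that something is new, unique, unknown or untested is made for them only; others in the source may bear on it.

Working notes on substituents at the sulfonyl sulfur of the shared core, read in a physicochemical assay for solubility, read by HPLC, using the shake flask method, measured as kinetic solubility, with a stated time of 20 h, at pH 6.5, tested at 200 uM; a lower number here means a less soluble compound, a higher number a more soluble compound. Compound 1 `O=S(=O)(CCO)c1cccc(-c2ccc3nccc(-c4ccncc4)c3n2)c1` gives 55000 nM. Compound 2 `NS(=O)(=O)c1cccc(-c2ccc3nccc(-c4ccncc4)c3n2)c1` returns only a limit, < 5000 nM. Compound 3 `O=S(=O)(c1cccc(-c2ccc3nccc(-c4ccncc4)c3n2)c1)N1CC[C@H](O)C1` gives 20000 nM, the lower of the two actual numbers, and the step to it is a 2.8-fold lower number from compound 1 to compound 3 (0.44 log units; beyond the scatter). It still lies clear of the limit, with an at least 4.0-fold higher number from compound 2 to compound 3 (0.60 log units; beyond the scatter). The remaining measured step is an at least 11-fold lower number from compound 1 to compound 2 (1.04 log units; beyond the scatter).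

Compound 4 `C[C@@H]1CN(S(=O)(=O)c2cccc(-c3ccc4nccc(-c5ccncc5)c4n3)c2)C[C@H](C)N1` carries 3,5-dimethylpiperazin-1-yl in place of 3-hydroxypyrrolidin-1-yl on a sulfonyl sulfur. Among the compounds with values here, all three measured steps change this same place, so they are the only guide to the size of the step, but none of them brings in the entering group. They range from modest to large, and neither direction is established for this exchange. The working expectation in this assay is therefore no step beyond the scatter, with a wide margin on either side. The expected change is a 1.4-fold higher number from compound 3 to compound 4 (0.15 log units; within the scatter). Compound 4 is estimated at 28000 nM, with an expected range of 7000 nM to 110000 nM.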

Compound 4, solubility: 180000 nM
Compound 4: the middle estimate sits 6.4-fold (0.81 log units) below what was measured; the whole stated range lies below it.
By their numbers in this assay, from the lowest: compound 3; then compound 1; then compound 4. At a limit, below all of these: compound 2.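

In this assay, the sulfonyl sulfur position can now move the number upward as well as downward: the earlier replacements of 2-hydroxyethyl both gave lower numbers, whereas 3,5-dimethylpiperazin-1-yl gives a 3.3-fold higher number from compound 1 to compound 4 (0.51 log units; beyond the scatter). Exchanging 3-hydroxypyrrolidin-1-yl for 3,5-dimethylpiperazin-1-yl gives a 9.0-fold higher number from compound 3 to compound 4 (0.95 log units; beyond the scatter), so two groups with the same donor and acceptor counts and no net charge still lie well apart in this series. The widest span now starts from the amino group, an at least 36-fold higher number from compound 2 to compound 4 (1.55 log units; beyond the scatter), and that span is a bound, not a measured gap: the limit of < 5000 nM in this assay, at which 1 of the 4 values shown sits.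

The compounds shown do not separate the second ring nitrogen, the two methyl groups and the six-membered ring as the feature that goes with the higher number, and piperazin-1-yl without the methyl groups or morpholin-4-yl would be the closest comparisons. From the compounds shown here alone, how a carboxylic acid or a longer aminoalkyl chain on the sulfonyl sulfur would read in this assay also remains open.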